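The source may hold more compounds than are shown below. What is called first, only, known or untested is meant among the compounds shown, and "the series" means these compounds.

Measured in a functional assay on HCT-116 cells (Homo sapiens) for cytotoxicity, read by MTT assay, with a stated time of 48 h; a lower number here means a stronger inhibitor of growth, a higher number a weaker inhibitor of growth:
Compound 1 `Cc1nc2cc(Cl)c(Cl)cc2[nH]1`: 51000 nM
Compound 2 `COc1cc2ncn([C@@H]3O[C@H](CO)[C@@H](O)[C@H]3O)c2cc1OC`: > 100000 nM (a limit)
Compound 3 `CCn1c(C(F)(F)F)nc2cc(Cl)c(Cl)cc21`: 95300 nM

Only two of these three results are numbers. Compound 1 gives 51000 nM and compound 3 gives 95300 nM, and these two values lie within the scatter of each other. For compound 2, the result of > 100000 nM is a limit of the assay.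

The next compound is compound 4 `Nc1cccc(Cn2c(C(F)(F)F)nc3cc(Cl)c(Cl)cc32)c1`, which has not yet been measured. It carries 3-aminophenyl in place of methyl on a saturated chain carbon bound to an aromatic nitrogen. Among the compounds with values here, no measured pair in this set shows the effect of a change at this place, so any forecast is loose. The estimated step of a 3.2-fold lower number from compound 3 to compound 4 (0.50 log units; beyond the scatter) is modest and is expected to point toward a lower number in this assay. For compound 4 the estimate is 30000 nM, with an expected range of 8000 nM to 90000 nM.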

Compound 4, concentration for 50% growth inhibition: 22600 nM
Compound 4: middle estimate off by 1.3-fold (0.12 log units), on the high side; low and high end bracket the measured number.
By their numbers in this assay, from the lowest: compound 4; then compounds 1 and 3 (each within the scatter of the next). At a limit, above all of these: compound 2.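

In this assay, within the data shown here, this is the first step that can be read at this place on the shared core: a 4.2-fold lower number from compound 3 to compound 4 (0.62 log units; beyond the scatter). It shows that 3-aminophenyl in place of methyl on a saturated chain carbon bound to an aromatic nitrogen does not cost growth inhibition; the number falls even though the entering group is far larger and adds an aromatic ring and an amine. Nothing measured here accounts for this step.

From the compounds shown here alone, whether the step comes from the ring itself or from its amine stays open, and a plain phenyl at the same place would separate the two. Also open, going by these compounds, is how a hydroxyl or a carboxylic acid on that ring, or a longer chain, would read, and this single pair sets no trend for any of them.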